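The source may report more compounds than this note shows. Statements on the series, on what has been measured and on what is new or still open speak of the compounds shown alone.

Measured compounds:
- compound 1, `COc1ccc(-c2cnc3nc(N)nc(N4CCN(C(=O)c5ccccc5)CC4)c3n2)cc1OC`: 400 nM
- compound 2, `CCOc1nc(N)nc2ncc(-c3ccc(C(F)(F)F)cc3)nc12`: 10000 nM
- compound 3, `COc1ccc(-c2cnc3nc(N)nc(N4CCC(C)CC4)c3n2)cc1OC`: 800 nM

These values come from a functional assay on cells (T-cell, Homo sapiens) for inhibition; a higher number here means a weaker inhibitor, a lower number a stronger inhibitor. Compound 1 has the lowest number of the three; compound 3 lies within the scatter of it, while compound 2 lies far beyond. Compound 4, `COc1ccc(-c2cnc3nc(N)nc(N4CCN(c5ccccc5)CC4)c3n2)cc1OC`, has not been measured. It differs from compound 1 in one place: phenyl in place of benzoyl on an amine nitrogen in a ring. Compound 3, which also lacks a carbonyl on its ring, stands within the scatter of compound 1, so no step beyond the scatter is expected here. The step from compound 1 to compound 4 is estimated as a 1.3-fold higher number from compound 1 to compound 4 (0.10 log units; within the scatter). Compound 4 is therefore expected to give about 500 nM in this assay, in a range from 150 nM to 1600 nM.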

Compound 4, half-maximal inhibitory concentration: 400 nM
Compound 4: middle estimate off by 1.3-fold (0.10 log units), on the high side, within the range that was stated.
By their numbers in this assay, from the lowest: compounds 1, 4 and 3 (each within the scatter of the next); then compound 2.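

In this assay, phenyl in place of benzoyl on the amine nitrogen in the ring gives no change at the digits printed from compound 1 to compound 4 (within the scatter) and so shows that, in this pair, the carbonyl of the benzoyl group can be lost without a step beyond the scatter. An aromatic ring bonded directly to this nitrogen reads the same as one attached through a carbonyl. Nothing at hand explains why the two groups read alike. Still open, as far as these compounds go, is how a smaller group on this nitrogen, such as methyl or acetyl, would read. Also open, from the compounds shown here alone, is how a longer link to the ring, as in benzyl, would read.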